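A few compounds are considered here, and "the series" means these few. Any claim that something is new, unique, unknown or untested is made for them only; others in the source may bear on it.

Compound 1 `COc1ccc(/C=C\C(=O)O)c(OCc2cn(-c3ccccc3C(=O)N3CCC(O)C3)nn2)c1CC=C(C)C` carries, on the aryl group attached to the triazole ring, a (3-hydroxypyrrolidin-1-yl)carbonyl group. In a functional assay on A549 cells (Homo sapiens) for cytotoxicity, read by MTT assay, with a stated time of 24 h (on this read-out lower numbers stand for stronger inhibition and higher numbers for weaker inhibition), compound 1 has "not determined" (no result reported) as its reported result, so it cannot be placed on the scale of numbers at all. Two related compounds were measured. Compound 2 `COc1ccc(/C=C\C(=O)O)c(OCc2cn(-c3ccccc3I)nn2)c1CC=C(C)C` bears a 2-iodophenyl on the aromatic nitrogen and gives 2200 nM in this assay. Compound 3 `COc1ccc(-n2cc(COc3c(/C=C\C(=O)O)ccc(OC)c3CC=C(C)C)nn2)cc1` bears a 4-methoxyphenyl there and gives 10200 nM. Going by the values given here, the only measured step is a 4.6-fold higher number from compound 2 to compound 3 (0.67 log units; beyond the scatter); it shows that swapping the aryl group on the aromatic nitrogen can shift the result by a modest amount, though the direction for any new aryl group cannot be read from a single pair.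

Compound 4 `COc1ccc(/C=C\C(=O)O)c(OCc2cn(-c3ccccc3)nn2)c1CC=C(C)C` differs from compound 1 as follows: hydrogen in place of (3-hydroxypyrrolidin-1-yl)carbonyl on an aromatic carbon. Among the compounds with values here, no measured step covers the removal of a substituent ortho to the large group, so the expectation for compound 4 rests only on the span between compound 2 and compound 3, both of which share the same core with compound 4. Compound 4 is therefore expected to fall within that span, at about 5000 nM, with a range from 2000 nM to 13000 nM in this assay.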

Compound 4, half-maximal inhibitory concentration: 40500 nM
Estimate against measurement, compound 4: 8.1-fold (0.91 log units) below, outside the stated range (above it).
By their numbers in this assay, from the lowest: compound 2; then compound 3; then compound 4.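

Hydrogen in place of methoxy gives a 4.0-fold higher number from compound 3 to compound 4 (0.60 log units; beyond the scatter) and hydrogen in place of iodo gives an 18-fold higher number from compound 2 to compound 4 (1.27 log units; beyond the scatter) in this assay on the same shared core. The earlier pair compared only two substituted aryl groups, whereas compound 4 adds the aryl group with no substituent at all, and it has the highest number of the three: both the 2-iodophenyl and the 4-methoxyphenyl go with lower numbers than plain phenyl, and no compound shown goes against this. No measurement shown here offers a reason for this order, or for the larger size of the step from iodo to hydrogen.

As far as these compounds go, the step between compound 1 and compound 4 cannot be read, since compound 1 has no number, so what the (3-hydroxypyrrolidin-1-yl)carbonyl does on this aryl group remains unknown. Also open, from the compounds shown here alone, is whether a smaller group such as an amine or a nitrile, or iodo and methoxy moved to other places on the same aryl group, would follow the same order.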